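Chloro in Place of Fluoro on the Benzyl Group

The source may report more compounds than this note shows. Statements on the series, on what has been measured and on what is new or still open speak of the compounds shown alone.

Measured compounds:
compound 1 `COc1ccc(-c2c(CO)n(Cc3cccc(F)c3)c3ccc(OC(F)(F)F)cc23)cn1`: > 10000 nM
compound 2 `COc1ccc(-c2c(CO)n(Cc3ccc(F)cc3F)c3ccc(OC(F)(F)F)cc23)cn1`: 5110 nM; 5130 nM (2 entries)
compound 3 `COc1ccc(-c2c(CO)n(Cc3cccc(C(F)(F)F)c3)c3ccc(OC(F)(F)F)cc23)cn1`: 4820 nM; 4790 nM (2 entries)

In an assay for antagonist activity at proteinase-activated receptor 4 (Homo sapiens) (a lower number here means a stronger inhibitor, a higher number a weaker inhibitor), compound 1 gives only a limit of the assay, > 10000 nM, and no number. Compound 2 gives 5110 nM; 5130 nM (2 entries) in this assay, and compound 3 gives 4820 nM; 4790 nM (2 entries) there; the repeated entries the several entries of compound 2 in this assay, 5110 nM; 5130 nM (2 entries) and the several entries of compound 3 in this assay, 4820 nM; 4790 nM (2 entries) agree closely. Compound 1 therefore stands at the limit (the limit of > 10000 nM in this assay, at which 1 of the 3 values shown sits), the only one of the three without a measured number, while compounds 2 and 3 lie within the measurable range and within the scatter of each other.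

Compound 4 `COc1ccc(-c2c(CO)n(Cc3cccc(Cl)c3)c3ccc(OC(F)(F)F)cc23)cn1` differs from compound 1 by chloro in place of fluoro on an aromatic carbon. For the measured compounds named here, no step between two measured compounds has been recorded, so the size of this change can only be guessed from the neighbours. Compounds 2 and 3 show that other changes on the same benzyl group bring the value down from the limit into the measurable range. A modest step toward stronger inhibition is expected from compound 1 to compound 4, yet a repeat of the limit remains quite possible. Compound 4 is estimated at 7000 nM in this assay, with a range from 3000 nM to 20000 nM. The step of an at least 1.4-fold lower number from compound 1 to compound 4 (0.15 log units; that floor lies within the scatter) is the expected size of that move.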

Compound 4, half-maximal inhibitory concentration: > 10000 nM
Compound 4 ended at the assay's limit (the forecaster's own chance of this, stated with the estimate: 35%); at least 1.4-fold (0.15 log units) between middle value and limit.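

In this assay compound 4 gives > 10000 nM, a limit and not a number. Compound 1 also stands at a limit, so the step between compound 1 and compound 4 cannot be read. The compounds shown leave open whether chloro in place of fluoro changes inhibition at all.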